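This account rests on a few compounds, and the source may have more. Where it says the series, first, only, none or still open, it means among the compounds named here.

The numbers come from a functional assay on NCI-H460 cells (Homo sapiens) for antiproliferative activity, read by sulforhodamine B assay, with a stated time of 48 h; a higher number here means a weaker inhibitor of growth, a lower number a stronger inhibitor of growth. Compound 3 `O=C1OC(CO)Cc2ccccc21` is one of the compounds for which only a limit is known: in this assay compound 3 gives >= 250 ug/mL, which is a limit of the assay and not a measured number. Compound 1 `O=c1oc(CO)cc2ccccc12` also stands at that limit, giving >= 250 ug/mL in this assay, again a limit rather than a number. Taken together, this is the limit of >= 250 ug/mL in this assay, at which 2 of the 3 values shown sit. For the measured compounds named here, the only numeric value comes from compound 2 `COc1ccc2cc(CCCO)oc(=O)c2c1`, which in this assay gives 29.1 ug/mL. Compound 2 and compound 3 differ in more than one place, so their two values show only that one of them reaches a number and the other stays at the limit.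

Compound 4 `COc1ccc2c(c1)C(=O)OC(CO)C2` has not yet been measured. It differs from compound 3 by methoxy in place of hydrogen on an aromatic carbon. Going by the values given here, no pair of measured compounds differs by this one change, so there is no direct guide for its size. Because compound 3 sits at a limit, any step can only be read if compound 4 gives a number at all. The step from compound 3 to compound 4 is expected to be an at least 1.3-fold lower number from compound 3 to compound 4 (0.14 log units; that floor lies within the scatter), that is, little change beyond the scatter. Compound 4 is therefore expected to give about 180 ug/mL in this assay, within a range from 50 ug/mL to 250 ug/mL, with a fair chance that only the limit is reported again.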

Compound 4, concentration for 50% growth inhibition: >= 250 ug/mL
Compound 4: a limit, no number; the forecaster's own chance of this, stated with the estimate: 60%; at least 1.3-fold (0.14 log units) between middle value and limit.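

Compound 3 and compound 4 both stay at a limit in this assay and give no number, so no step can be read between them, and the result simply joins the others there: the limit of >= 250 ug/mL in this assay, at which 3 of the 4 values shown sit. The compounds shown leave open whether methoxy in place of hydrogen on an aromatic carbon changes growth inhibition at all.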